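The source may report more compounds than this note shows. Statements on the series, on what has been measured and on what is new or still open speak of the compounds shown alone.

Measured so far:
compound 1 `C[C@@H](NC(=O)c1ccc(C#Cc2ccc(F)cc2F)cn1)C(C)(C)O`: 61.2%
compound 2 `Cc1ccccc1C#Cc1ccc(C(=O)N[C@H](C)C(C)(C)O)nc1`: 59.9%

In a functional assay on HEK293 cells for positive allosteric modulation of metabotropic glutamate receptor 5 (Rattus norvegicus), read by fluorescence and calcium flux (a higher number here means a larger maximal response, a lower number a smaller maximal response), compound 2 gives 59.9%, one of two numbers that sit close together; the step of a number 1.3 percentage points lower from compound 1 to compound 2 (within the scatter) lies within the scatter. Compound 3 `Cc1cccc(C#Cc2ccc(C(=O)N[C@H](C)C(C)(C)O)nc2)c1` differs from compound 2 by 3-methylphenyl in place of 2-methylphenyl on a triple-bonded carbon. Going by the values given here, the only measured step at this place, a number 1.3 percentage points lower from compound 1 to compound 2 (within the scatter), exchanged one whole aryl group for another without moving the number beyond the scatter. Among the compounds with values here, no measured step shifts a methyl around the phenyl, so no change beyond the scatter is expected here. Compound 3 is therefore estimated at 58%, with a range from 42% to 74%. The expected step is a number 1.9 percentage points lower from compound 2 to compound 3 (within the scatter).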

Compound 3, largest response reached (reported as efficacy), in percent of the reference or control that the assay uses: 68.6%
The estimate for compound 3 lay 10.6 percentage points below the measured number; the range from low to high includes it.
By their numbers in this assay, from the lowest: compounds 2, 1 and 3 (each within the scatter of the next).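

In this assay, the shift from 2-methylphenyl to 3-methylphenyl on the triple-bonded carbon gives a number 8.7 percentage points higher from compound 2 to compound 3 (within the scatter), and the exchange of the whole aryl group gives a number 7.4 percentage points higher from compound 1 to compound 3 (within the scatter). Neither step separates the compounds, so the 2-methylphenyl, 3-methylphenyl and 2,4-difluorophenyl groups cannot be told apart here, whether the methyl shifts or the aryl group changes. No measurement at hand bears on the reason for these numbers.

Still open, on these data alone, is whether a longer chain in place of the methyl would carry the number beyond the scatter. The same holds for an amine or a carboxylic acid on the phenyl ring.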